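Swapping the Naphthyl Group for Nitrophenyl in Compound 1

The source may hold more compounds than are shown below. What is called first, only, known or untested is meant among the compounds shown, and "the series" means these compounds.

Three compounds built on one shared core were tested in a functional assay on Ehrlich cells (Mus musculus) for cytotoxicity, tested at 50 ug/mL; on this read-out higher numbers stand for a stronger effect at the one concentration tested and lower numbers for a weaker effect. Compound 1 `COc1cc(N2C(N)=C(C#N)C(c3c(O)ccc4ccccc34)C3=C2CC(C)(C)CC3=O)cc(OC)c1OC` gives 15%, the lowest of the three numbers. Compound 2 `COc1cc(N2C(N)=C(C#N)C(c3ccc(OC)c4ccccc34)C3=C2CC(C)(C)CC3=O)cc(OC)c1OC` gives 40%, and compound 3 `COc1ccccc1C1C(C#N)=C(N)N(c2cc(OC)c(OC)c(OC)c2)C2=C1C(=O)CC(C)(C)C2` gives 70%, so compound 1 sits beyond the scatter below both of them.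

The unmeasured compound 4 `COc1cc(N2C(N)=C(C#N)C(c3ccc([N+](=O)[O-])cc3)C3=C2CC(C)(C)CC3=O)cc(OC)c1OC` differs from compound 1 in a single place: 4-nitrophenyl in place of 2-hydroxynaphthalen-1-yl on a saturated ring carbon. Two measured steps change the group on that same saturated ring carbon. The step of a number 25 percentage points higher from compound 1 to compound 2 (beyond the scatter) came with 4-methoxynaphthalen-1-yl, and the step of a number 55 percentage points higher from compound 1 to compound 3 (beyond the scatter) came with 2-methoxyphenyl. Both point upward, and the larger rise came with the group of one aromatic ring. Compound 4 likewise carries a group of one aromatic ring there, and with the step of a number 55 percentage points higher from compound 1 to compound 3 (beyond the scatter) as the closest guide, a rise beyond the scatter is expected in this assay, of about a number 35 percentage points higher from compound 1 to compound 4 (beyond the scatter). Compound 4 is therefore estimated at 50%, with a range from 25% to 75%.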

Compound 4, a percentage reported as activity, at one concentration (the size of the read-out at that concentration, not a potency): 70%
Compound 4: middle estimate off by 20 percentage points, on the low side, within the range that was stated.
By their numbers in this assay, from the lowest: compound 1; then compound 2; then compounds 3 and 4 (each within the scatter of the next).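

In this assay, placing 4-nitrophenyl on this saturated ring carbon gives a number 55 percentage points higher from compound 1 to compound 4 (beyond the scatter) and a number 30 percentage points higher from compound 2 to compound 4 (beyond the scatter), so a second group of one aromatic ring now stands clear of both naphthyl compounds. Against 2-methoxyphenyl the swap gives no change at the digits printed from compound 3 to compound 4 (within the scatter), so two different substituents on a single aromatic ring read alike, and none of these four compounds goes against the split between groups of one aromatic ring and groups of two. Nothing available explains that split.

The compounds shown leave open how a plain phenyl group, or a phenyl group carrying an amine or a carboxylic acid, would read at this carbon. They also leave open whether 2-nitrophenyl or 3-nitrophenyl would read like 4-nitrophenyl.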